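The source may report more compounds than this note shows. Statements on the series, on what has been measured and on what is new or still open speak of the compounds shown alone.

Compound 1 `C=C1C(=O)[C@]23C[C@@]1(O)CC[C@H]2c1ccc(OS(=O)(=O)c2ccc(C)cc2)c(C)c1[C@@H]3Cn1cc(-c2ccc(Br)cc2)nn1` is the starting point of this comparison. In a functional assay on HL-60 cells (Homo sapiens) for cytotoxicity, read by MTT assay, with a stated time of 4 days (on this read-out higher numbers stand for weaker inhibition and lower numbers for stronger inhibition), compound 1 gives 1020 nM. Compound 2 `C=C1C(=O)[C@]23C[C@@]1(O)CC[C@H]2c1ccc(O)c(C)c1[C@@H]3Cn1cc(-c2ccc(Br)cc2)nn1`, which carries hydrogen in place of (4-methylphenyl)sulfonyl on an oxygen on an aromatic ring, gives 560 nM in this assay; the step of a 1.8-fold lower number from compound 1 to compound 2 (0.26 log units; within the scatter) stays within the scatter, so these two compounds cannot be told apart on the numbers available. Compound 3 `C=C1C(=O)[C@]23C[C@@]1(O)CC[C@H]2c1ccc(OS(=O)(=O)c2ccc(C)cc2)c(C)c1[C@@H]3Cn1cc(-c2ccc(OC)cc2)nn1` differs from compound 1 by methoxy in place of bromo on an aromatic carbon. Among the compounds with values here, no measured step touches that part of the molecule: the only known step changes a different group and is itself within the scatter, so it gives no direction for this one. The expected step of no change at the digits printed from compound 1 to compound 3 (within the scatter) is accordingly no change beyond the scatter. Compound 3 is estimated at 1020 nM in this assay, with a range from 400 nM to 2600 nM.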

Compound 3, half-maximal inhibitory concentration: 1020 nM
Estimate against measurement, compound 3: no gap at the digits printed; measured number inside the range.
By their numbers in this assay, from the lowest: compounds 2, 1 and 3 (each within the scatter of the next).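

Within the data shown here, compound 3 is the first compound here to change the far end of the molecule, at the place para to a large group on a six-membered aromatic ring of carbon only. In this assay, replacing bromo with methoxy gives (no change at the digits printed from compound 1 to compound 3 (within the scatter)), so on this single pair, a halogen and an oxygen-linked group that adds a hydrogen-bond acceptor cannot be told apart at this position. No available evidence explains this result.

This pair tests only one replacement and only with the (4-methylphenyl)sulfonyl group in place, so the same change on compound 2, which has hydrogen there instead, remains an open question. On these data alone, it also remains open whether an amine, a carboxylic acid or a longer chain at this position would leave the number within the scatter.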